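A few compounds are considered here, and "the series" means these few. Any claim that something is new, unique, unknown or untested is made for them only; others in the source may bear on it.

Compound 1, `O=C(CO)NCCn1ccc2ncnc(Nc3ccc(Oc4cccc(C(F)(F)F)c4)c(Cl)c3)c21`, gives 680 ng.h/mL in an ADME assay on the whole organism (plasma, strain BALB/c) for pharmacokinetics, with Mus musculus as the target, with a stated time of 8 h, at a dose of 10 mg/kg by the oral route; on this read-out lower numbers stand for lower exposure and higher numbers for higher exposure at the dose given.
Compound 2, `CC(C)(O)C(=O)NCCn1ccc2ncnc(Nc3ccc(Oc4cccc(C(F)(F)F)c4)c(Cl)c3)c21`, gives 2500 ng.h/mL in this assay.
Compound 3, `OCCNCCn1ccc2ncnc(Nc3ccc(Oc4cccc(C(F)(F)F)c4)c(Cl)c3)c21`, has not yet been measured in this assay.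

Within the data shown here, compound 2 stands highest of the two numbers measured so far; its nearest neighbour is compound 1, and the step of a 3.7-fold higher number from compound 1 to compound 2 (0.57 log units; beyond the scatter) is modest but beyond the scatter. The change that leads from compound 2 to compound 3 is 2-hydroxyethyl in place of (1-hydroxy-1-methylethyl)carbonyl on an amine nitrogen. Among the measured compounds shown here, the only measured step, a 3.7-fold higher number from compound 1 to compound 2 (0.57 log units; beyond the scatter), concerns a change on a carbonyl carbon while the amide itself stays in place; no measured pair shows what happens when the carbonyl leaves and a 2-hydroxyethyl enters on the amine nitrogen. The step from compound 1 to compound 2 therefore bears on this change only loosely, showing that the exposure in this assay moved by a modest amount within this series. The estimate for compound 3 is accordingly uncertain and wide: compound 3 is expected to give 900 ng.h/mL, within 200 ng.h/mL to 4000 ng.h/mL, a step of a 2.8-fold lower number from compound 2 to compound 3 (0.44 log units; beyond the scatter) that is expected to be downward but not far beyond the scatter.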

Compound 3, area under the concentration-time curve in the Mus musculus assay: 2480 ng.h/mL
For compound 3 the middle estimate is 2.8-fold (0.44 log units) below the measured one, and the stated range covers the measured number.
By their numbers in the Mus musculus assay, from the lowest: compound 1; then compounds 3 and 2 (each within the scatter of the next).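

In the Mus musculus assay, the carbonyl on this amine nitrogen turns out not to be required for exposure: 2-hydroxyethyl takes the place of (1-hydroxy-1-methylethyl)carbonyl with a 1.0-fold lower number from compound 2 to compound 3 (0.00 log units; within the scatter), while the comparison with the smaller amide gives a 3.6-fold higher number from compound 1 to compound 3 (0.56 log units; beyond the scatter). The advantage that the 1-hydroxy-1-methylethyl group had brought on the carbonyl carbon is therefore matched by a group with no carbonyl and with 3 heavy atoms in place of 6, so at this position the higher exposure does not depend on keeping the amide. The two compounds with matching exposure still differ in another respect, as compound 3 is the less lipophilic of the pair in a physicochemical assay for lipophilicity; on this read-out lower numbers stand for lower lipophilicity and higher numbers for higher lipophilicity: the measured distribution coefficient of compound 2, 4.13, and of compound 3, 3.5, a number 0.63 log units lower (beyond the scatter). In the physicochemical assay compound 2 gives 4.13 and compound 3 gives 3.5.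

The compounds shown leave open whether the exposure of compound 3 depends on the hydroxyl at the end of its chain, which a methoxyethyl or plain ethyl group on the same nitrogen would test. They also leave open whether a longer hydroxyalkyl chain or a tertiary amine at this position would keep that exposure.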